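Compound 4: methyl in place of trifluoromethyl

The source may report more compounds than this note shows. Statements on the series, on what has been measured and on what is new or still open speak of the compounds shown alone.

In a functional assay on the whole organism with Mus musculus as the target, in the maximal electroshock model (on this read-out higher numbers stand for an effect only at larger amounts of compound and lower numbers for an effect already at smaller amounts), compound 1 `OC1CCN(c2ccc(-c3cccc(Cl)c3)nn2)CC1` gives 45 mg/kg while compound 2 `O=[N+]([O-])c1cccc(-c2ccc(N3CCC(O)CC3)nn2)c1` gives 79 mg/kg and compound 3 `OC1CCN(c2ccc(-c3cccc(C(F)(F)F)c3)nn2)CC1` gives 63 mg/kg as its value. Compound 3 stands within the scatter of both other compounds. The next structure is compound 4 `Cc1cccc(-c2ccc(N3CCC(O)CC3)nn2)c1` with methyl in place of trifluoromethyl on an aromatic carbon. Three measured exchanges on an aromatic carbon bear on it. Trifluoromethyl in place of chloro gives a 1.4-fold higher number from compound 1 to compound 3 (0.15 log units; within the scatter) and nitro in place of chloro gives a 1.8-fold higher number from compound 1 to compound 2 (0.24 log units; within the scatter) while trifluoromethyl in place of nitro gives a 1.3-fold lower number from compound 2 to compound 3 (0.10 log units; within the scatter) on the same scale. Among the compounds with values here, none of these steps leaves the scatter, and no compound carrying methyl has been measured yet. No step beyond the scatter is therefore expected in this assay and no firm direction can be given. The expected step is a 1.1-fold lower number from compound 3 to compound 4 (0.02 log units; within the scatter) as estimated here. For compound 4 the estimated value is 60 mg/kg with an expected range from 30 mg/kg to 120 mg/kg for now.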

Compound 4, dose for half-maximal effect: 36 mg/kg
Compound 4: middle estimate off by 1.7-fold (0.22 log units), on the high side; low and high end bracket the measured number.
By their numbers in this assay, from the lowest: compounds 4, 1, 3 and 2 (each within the scatter of the next, the first and the last beyond it).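

In this assay this aromatic carbon gives its first step beyond the scatter: methyl in place of nitro gives a 2.2-fold lower number from compound 2 to compound 4 (0.34 log units; beyond the scatter) as a modest change. Methyl in place of trifluoromethyl gives a 1.8-fold lower number from compound 3 to compound 4 (0.24 log units; within the scatter) and methyl in place of chloro gives a 1.3-fold lower number from compound 1 to compound 4 (0.10 log units; within the scatter) on the same scale, so among the four groups only the methyl and nitro pair separates, and only narrowly. Nothing available here accounts for that separation.

Still open, from the compounds shown here alone, is whether a group of another kind at this place, such as an amine, a methoxy group or a longer alkyl chain, moves the number further from that of compound 4. Also open, going by these compounds, is whether the methyl and nitro gap holds when the hydroxyl group on the shared core is exchanged.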